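Three compounds on one core, one tail swap ahead

The source may report more compounds than this note shows. Statements on the series, on what has been measured and on what is new or still open speak of the compounds shown alone.

Three compounds have been measured in an ADME assay on the whole organism (Mus musculus, strain Balb/c) for pharmacokinetics, at a dose of 10 mg/kg by the oral route; a higher number here means more compound in the circulation at the dose given, a lower number less compound in the circulation:

compound 3 `Cc1nn(CC(=O)N2CCN(c3sc(C(F)(F)F)nc3-c3nc4ccccc4[nH]3)C[C@H]2C)cc1CN(C)C` gives 833 ng.h/mL
compound 2 `C[C@@H]1CN(c2sc(C(F)(F)F)nc2-c2nc3ccccc3[nH]2)CCN1C(=O)Cn1cccn1` gives 720 ng.h/mL
compound 1 `C[C@@H]1CN(c2sc(C(F)(F)F)nc2-c2nc3cc(OCCO)ccc3[nH]2)CCN1C(=O)Cn1cnc2cccnc21` gives 519 ng.h/mL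

Compound 3 has the largest of the three numbers, yet its gaps to compound 2 and to compound 1 both lie within the scatter, so the three compounds cannot be told apart on this assay. For the measured compounds named here, the only measured step that touches the tail is a 1.2-fold higher number from compound 2 to compound 3 (0.06 log units; within the scatter), a change on the same position that left the number essentially where it was.

Compound 4 `C[C@@H]1CN(c2sc(C(F)(F)F)nc2-c2nc3ccccc3[nH]2)CCN1C(=O)Cn1cnc2cccnc21` differs from compound 3 in exactly that tail: a group of 9 heavy atoms (6 carbon, 3 nitrogen; one five-membered aromatic ring with 2 hetero atoms, one six-membered aromatic ring with 1 hetero atom) in place of a group of 10 heavy atoms (7 carbon, 3 nitrogen; one five-membered aromatic ring with 2 hetero atoms), on a saturated chain carbon bound to a carbonyl carbon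

Going by the values given here, the entering group is the tail already carried by compound 1, whose number sits within the scatter of compound 3, although compound 1 also differs elsewhere on the core, so no clean step exists for it. Given that the one tail step, a 1.2-fold higher number from compound 2 to compound 3 (0.06 log units; within the scatter), stayed within the scatter, the expected step for compound 4 is a 1.3-fold lower number from compound 3 to compound 4 (0.13 log units; within the scatter), with no direction beyond the scatter. Compound 4 is therefore estimated at 620 ng.h/mL, expected to fall between 300 ng.h/mL and 1250 ng.h/mL.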

Compound 4, area under the concentration-time curve in the Mus musculus assay: 2890 ng.h/mL
Compound 4: the middle estimate sits 4.7-fold (0.67 log units) below what was measured, outside the stated range (above it).
By their numbers in the Mus musculus assay, from the lowest: compounds 1, 2 and 3 (each within the scatter of the next); then compound 4.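

The tail at this place, on a saturated chain carbon bound to a carbonyl carbon, now clearly counts in the Mus musculus assay: the group with two aromatic rings gives a 3.5-fold higher number from compound 3 to compound 4 (0.54 log units; beyond the scatter) and a 4.0-fold higher number from compound 2 to compound 4 (0.60 log units; beyond the scatter), whereas the earlier swap between two pyrazole tails stayed within the scatter. With this tail held fixed, the core also counts, since hydrogen in place of 2-hydroxyethoxy on an aromatic carbon gives a 5.6-fold higher number from compound 1 to compound 4 (0.75 log units; beyond the scatter). In a physicochemical assay for solubility, in simulated intestinal fluid (a higher number here means a more soluble compound, a lower number a less soluble compound), compound 3 gives 645 ug/mL and compound 4 gives 214 ug/mL, so the higher number in the circulation came with the lower solubility.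

Only one two-ring tail appears here, so the compounds shown cannot say whether the second ring or the nitrogen in it matters. An indol-1-yl tail, whose six-membered ring holds only carbon, would separate the two.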